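Pentyl for Methoxycarbonyl on Two Triazole Side Chains

The source may report more compounds than this note shows. Statements on the series, on what has been measured and on what is new or still open speak of the compounds shown alone.

Four compounds sharing a five-membered aromatic core were compared in a physicochemical assay for lipophilicity, measured as octanol-water partition; a higher number here means a more lipophilic compound, a lower number a more polar compound. In this assay compound 1 `CCCCCc1cn(CC=C(C)C)nn1` gives 3.46, while compound 2 `COC(=O)c1cn(CC=C(C)C)nn1` gives 1.3. The step of a number 2.16 log units higher from compound 2 to compound 1 (beyond the scatter) corresponds to pentyl in place of methoxycarbonyl on an aromatic carbon. Compound 3 `COC(=O)c1cn(C/C=C(\C)CC/C=C(\C)CCC=C(C)C)nn1` carries a much longer chain on the ring nitrogen; in this assay compound 3 gives 5.25, the highest of the three measured numbers. The difference between the core of compound 2 and the core of compound 3 is not broken down here.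

Compound 4 `CCCCCc1cn(C/C=C(\C)CC/C=C(\C)CCC=C(C)C)nn1` has not yet been measured. It differs from compound 3 by pentyl in place of methoxycarbonyl on an aromatic carbon. For the measured compounds named here, this is the same kind of change as the one from compound 2 to compound 1, although around the place the ring atom bears a large group in compound 3 and a group of 5 heavy atoms in compound 2. Because the earlier change gave a number 2.16 log units higher from compound 2 to compound 1 (beyond the scatter), a step of similar size, a number 2.05 log units higher from compound 3 to compound 4 (beyond the scatter), is expected for compound 4. Compound 4 is therefore estimated at 7.3, with a likely range from 6.6 to 7.9.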

Compound 4, partition coefficient: 7.5
Beside the measured number, compound 4's estimate is 0.20 log units below it; low and high end bracket the measured number.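

In this assay, pentyl in place of methoxycarbonyl on an aromatic carbon gave a number 2.25 log units higher from compound 3 to compound 4 (beyond the scatter), and the same change on the other core gave a number 2.16 log units higher from compound 2 to compound 1 (beyond the scatter). Both steps are large and point the same way, so the change carried from the core of compound 2 to the core of compound 3, even though the group on the ring nitrogen differs greatly, but two pairs show this for these cores only and not for the series as a whole. Nothing available here explains the size of either step.

The compounds shown leave open what other groups would do at the same aromatic carbon on these two cores, such as an amine, a carboxylic acid or a chain longer than pentyl. They also leave open whether the step would hold with a different chain on the ring nitrogen, such as a plain hexyl chain.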